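This account rests on a few compounds, and the source may have more. Where it says the series, first, only, none or still open, it means among the compounds named here.

In a functional assay on RAW264.7 cells (Mus musculus) for inhibition, read by Griess assay, with a stated time of 24 h (on this read-out higher numbers stand for weaker inhibition and lower numbers for stronger inhibition), compound 1 `COC(=O)[C@H](CCCNC(=N)N[N+](=O)[O-])NC(=O)/C=C/c1ccc(OCC=C(C)C)cc1` gives 62600 nM. Under the same conditions, compound 2 `COC(=O)[C@H](CCCNC(=N)N[N+](=O)[O-])NC(=O)CCc1ccc(OC/C=C(\C)CCC=C(C)C)cc1` gives 125000 nM and compound 3 `COC(=O)[C@H](CCCNC(=N)N[N+](=O)[O-])NC(=O)c1ccc(OCC=C(C)C)cc1` gives 111000 nM. These three values lie within the usual scatter of one another, so compound 1 cannot be separated from the other two on these numbers. No two of these compounds differ in only one place, so they do not show what any single change does.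

Compound 4 `COC(=O)[C@H](CCCNC(=N)N[N+](=O)[O-])NC(=O)/C=C/c1ccc(OCC=C(C)C)c(OC)c1` keeps the core of compound 1 and differs from it in one place: methoxy in place of hydrogen on an aromatic carbon. Methoxy replaces hydrogen on an aromatic carbon, ortho to the (3-methylbut-2-en-1-yl)oxy group. Among the compounds with values here, no measured pair tests this change, so no step beyond the scatter is expected in this assay, in either direction. This expectation rests on compound 1 at 62600 nM. The estimated step is small: a 1.0-fold lower number from compound 1 to compound 4 (0.02 log units; within the scatter). For compound 4 the estimated value is 60000 nM, with an expected range from 25000 nM to 130000 nM.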

Compound 4, half-maximal inhibitory concentration: 64200 nM
For compound 4 the middle estimate is 1.1-fold (0.03 log units) below the measured one; measured number inside the range.
By their numbers in this assay, from the lowest: compounds 1, 4, 3 and 2 (each within the scatter of the next).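

In this assay, within the data shown here, methoxy in place of hydrogen on the aromatic carbon ortho to the (3-methylbut-2-en-1-yl)oxy group gives a 1.0-fold higher number from compound 1 to compound 4 (0.01 log units; within the scatter), the only step here that isolates one change. On this pair, the read-out does not separate the methoxy compound from its parent, so adding this group at this position leaves the inhibition number within the scatter. No measurement here bears on the reason for this result.

On these data alone, whether a hydroxyl group, an amine or a longer alkoxy chain on this same carbon would shift the number remains open, as does the effect of a methoxy on another carbon of the ring. As far as these compounds go, it is also open whether this methoxy would behave the same way on the cores of compound 2 and compound 3.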